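From piperidin-4-yl to 1,4-diazepan-1-yl on the shared core

A few compounds are considered here, and "the series" means these few. Any claim that something is new, unique, unknown or untested is made for them only; others in the source may bear on it.

Measured so far in a physicochemical assay for solubility, read by HPLC, using the shake flask method, in phosphate buffer, with a stated time of 20 h, at pH 6.5; on this read-out higher numbers stand for higher solubility and lower numbers for lower solubility
- Compound 1 `CN1CCN(c2nccc3nc(-c4ccc(F)c(F)c4)[nH]c23)CC1` gives 130000 nM
- Compound 2 `Fc1ccc(-c2nc3c(C4CCNCC4)nccc3[nH]2)cc1F` gives 200000 nM
- Compound 3 `C[C@@H]1CN(c2nccc3[nH]c(-c4ccc(F)c(F)c4)nc23)C[C@H](C)N1C` gives 50000 nM

Compound 2, at 200000 nM, cannot be told apart from compound 1 within the scatter, while compound 3 lies clearly lower. Compound 4 `Fc1ccc(-c2nc3c(N4CCCNCC4)nccc3[nH]2)cc1F`, not yet measured, carries 1,4-diazepan-1-yl in place of piperidin-4-yl on an aromatic carbon. Among the measured compounds shown here, no measured step shows this change directly. The expectation rests on the other groups at this place: compound 1 gives 130000 nM and compound 3 gives 50000 nM. The expected step of a 1.5-fold lower number from compound 2 to compound 4 (0.19 log units; within the scatter) is a small fall, within the scatter. For compound 4 the estimated value is 130000 nM, with an expected range of 50000 nM to 350000 nM.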

Compound 4, solubility: 165000 nM
For compound 4 the middle estimate is 1.3-fold (0.10 log units) below the measured one; the measured number falls inside the stated range.
By their numbers in this assay, from the lowest: compound 3; then compounds 1, 4 and 2 (each within the scatter of the next).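

Placing 1,4-diazepan-1-yl in position of piperidin-4-yl on this aromatic carbon gives the first direct step at this place in this assay: a 1.2-fold lower number from compound 2 to compound 4 (0.08 log units; within the scatter) in the read-out. The two compounds cannot be told apart, even though a seven-membered ring with 2 hetero atoms replaces a six-membered ring with 1. No measurement here accounts for this. Still open, on these data alone, is how this place would read with a ring lacking the second amine nitrogen, such as morpholin-4-yl, or with an open-chain amine or a carboxylic acid.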